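Pentyl Ether to Propanoyl Ester: Expected Cytotoxicity Outcome

A few compounds are considered here, and "the series" means these few. Any claim that something is new, unique, unknown or untested is made for them only; others in the source may bear on it.

Three compounds have been measured in a functional assay on A549 cells (Homo sapiens) for cytotoxicity, with a stated time of 48 h; on this read-out higher numbers stand for weaker inhibition and lower numbers for stronger inhibition:

compound 1 `CCCCCOc1ccc2oc(/C=C/[S+](C)[O-])cc(=O)c2c1` — 1600 nM
compound 2 `Cc1cccc2oc(/C=C/[S+](C)[O-])cc(=O)c12` — 1300 nM
compound 3 `C[S+]([O-])/C=C/c1oc2ccccc2c(=O)c1Cc1ccccc1` — 1300 nM

Compound 1 gives the highest of the three numbers, yet its gaps to compound 2 and to compound 3 both lie within the usual scatter, so no order can be read among them; the three sit as a tight cluster. Compound 4 `CCC(=O)Oc1ccc2oc(/C=C/[S+](C)[O-])cc(=O)c2c1` has not yet been measured. It differs from compound 1 in one place: propanoyl in place of pentyl on an oxygen on an aromatic ring. Going by the values given here, no measured pair shows what this kind of change does on this read-out, so there is no step to lean on. Since compound 1, compound 2 and compound 3 land close together despite differing in several ways, the expected step in this assay is no change at the digits printed from compound 1 to compound 4 (within the scatter), meaning none beyond the scatter. The estimate for compound 4 is 1600 nM, with a range from 600 nM to 4500 nM.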

Compound 4, half-maximal inhibitory concentration: 2400 nM
Compound 4: the middle estimate sits 1.5-fold (0.18 log units) below what was measured; low and high end bracket the measured number.
By their numbers in this assay, from the lowest: compounds 2, 3, 1 and 4 (each within the scatter of the next).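

In this assay, putting propanoyl in place of pentyl on this oxygen gives a 1.5-fold higher number from compound 1 to compound 4 (0.18 log units; within the scatter), a step within the scatter. Going by these compounds alone, this is the first single-place comparison, and it shows that this ether-to-ester swap, which also adds a hydrogen-bond acceptor, brings no readable change at this position. Nothing measured here offers an explanation for this result. Still open, going by these compounds, is whether an amine, a carboxylic acid or a chain longer than pentyl at this oxygen would move the number beyond the scatter.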